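Removing Drawn Stereochemistry from a Two-Headed Exchanger Inhibitor

A few compounds are considered here, and "the series" means these few. Any claim that something is new, unique, unknown or untested is made for them only; others in the source may bear on it.

Compound 2 `CN1Cc2c(Cl)cc(Cl)cc2[C@H](c2cccc(S(=O)(=O)NCCOCCOCCOCCNC(=O)NCCOCCOCCOCCNS(=O)(=O)c3cccc([C@@H]4CN(C)Cc5c(Cl)cc(Cl)cc54)c3)c2)C1` is built from identical end groups joined by a long chain. In an assay on cells (Kidney epithelial cell, kidney) for inhibition of sodium/hydrogen exchanger 3 (Homo sapiens), read by fluorescence, in the presence of a further agent that is not named here (a higher number here means a weaker inhibitor, a lower number a stronger inhibitor), compound 2 gives 7.94 nM, level at the digits reported with compound 1 `CN1Cc2c(Cl)cc(Cl)cc2[C@H](c2cccc(S(=O)(=O)NCCOCCOCCNC(=O)COCC(=O)NCCOCCOCCNS(=O)(=O)c3cccc([C@@H]4CN(C)Cc5c(Cl)cc(Cl)cc54)c3)c2)C1`, which gives 7.94 nM. Compound 3 `CN1Cc2c(Cl)cc(Cl)cc2C(c2cccc(S(=O)(=O)NCCOCCOCCOCCNC(=O)NCCOCCOCCOCCNS(=O)(=O)c3cccc(C4CN(C)Cc5c(Cl)cc(Cl)cc54)c3)c2)C1` has the same atoms and bonds: the two compounds have the same atoms and bonds; at least one stereo element is drawn with a configuration in one of them and without one in the other: 2 of 2 stereo elements differ; a stereocentre at a saturated ring carbon is drawn S in compound 2 and without a configuration in compound 3; a stereocentre at a saturated ring carbon is drawn S in compound 2 and without a configuration in compound 3. Compound 3 may thus be a mixture of stereoisomers rather than one defined form. A small loss, at most near the edge of the scatter, is expected, so the step of a 1.6-fold higher number from compound 2 to compound 3 (0.21 log units; within the scatter) is estimated. Compound 3 is expected at 13 nM, within 5 nM to 40 nM.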

Compound 3, half-maximal inhibitory concentration: 200 nM
Beside the measured number, compound 3's estimate is 15-fold (1.19 log units) below it, and the stated range ends below it.
By their numbers in this assay, from the lowest: compounds 1 and 2 (each within the scatter of the next); then compound 3.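

In this assay, the configuration at the two saturated ring carbons proves to matter, with a 25-fold higher number from compound 2 to compound 3 (1.40 log units; beyond the scatter). Compounds 1 and 2 both carry the S configuration drawn at these carbons, so neither could show this. The change therefore points to stereochemistry alone, as the only difference is this: the fact that one of compounds 2 and 3 is drawn with a defined configuration and the other without, at the place where they differ

The compounds shown leave open which stereoisomers are present in compound 3 and how each behaves, including the form drawn R at both ring carbons. Going by these compounds, whether a longer chain between the end groups would show the same sensitivity also remains open.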